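The source may report more compounds than this note shows. Statements on the series, on what has been measured and on what is new or still open speak of the compounds shown alone.

Measured so far in an ADME assay on HepG2 cells (Homo sapiens) for cytotoxicity, read by luminescence, with a stated time of 72 h; on this read-out lower numbers stand for an effect already at smaller amounts and higher numbers for an effect only at larger amounts of compound:
Compound 1 `CCOC(=O)c1c(-c2cccc(-c3ccccc3)c2)[nH]c2cc(OC)c(F)cc2c1=O`: > 21500 nM
Compound 2 `CCOC(=O)c1c(-c2cccc(OC(F)(F)F)c2)[nH]c2cc(OC)c(F)cc2c1=O`: > 21500 nM

Neither entry is a number. Compound 2 gives only a limit of the assay, > 21500 nM. Compound 1 also gives only a limit, > 21500 nM.

The next compound to be tested is compound 3 `CCOC(=O)c1c(-c2cccc(F)c2)[nH]c2cc(OC)c(F)cc2c1=O`. It carries fluoro in place of trifluoromethoxy on an aromatic carbon of a six-membered aromatic ring of carbon only, meta to a large group (fluoro in place of trifluoromethoxy on an aromatic carbon).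

Among the measured compounds shown here, one measured step bears on this change, since it replaces a group at the same place: a step that the two limits leave unreadable from compound 1 to compound 2. It has no size that could be carried over. All that can be said is that both measured compounds sit at one ceiling, (the limit of > 21500 nM in this assay, at which 2 of the 2 values shown sit). With phenyl and trifluoromethoxy each ending there, the smaller fluoro is expected to end there as well, and no shift beyond the scatter is foreseen in this assay. The estimated step is a step that the limit leaves unreadable from compound 2 to compound 3. For compound 3 the expected value is 25000 nM, with an estimated range from 14000 nM to 45000 nM, and the read-out will most likely be a limit once more.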

Compound 3, half-maximal effective concentration: > 21500 nM
Compound 3 was reported as a limit; the forecaster's own chance of this, stated with the estimate: 85%; the middle value does not contradict the limit.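

Among the compounds shown here, compound 3 gives only a limit of the assay, > 21500 nM, so no step linking it to compound 1 or compound 2 can be read in this assay. The compounds shown leave open whether phenyl, trifluoromethoxy and fluoro differ at all in this assay, since none of the three compounds has a measured number: the limit of > 21500 nM in this assay, at which 3 of the 3 values shown sit.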